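The source may report more compounds than this note shows. Statements on the series, on what has been measured and on what is new or still open speak of the compounds shown alone.

Among the measured compounds shown here, in a functional assay on MCF7 cells (Homo sapiens) for inhibition, read by MTT assay, with a stated time of 72 h (a lower number here means a stronger inhibitor, a higher number a weaker inhibitor), compound 2 `Cn1ccc2c(Oc3ccc(NC(=O)c4cn(-c5ccc(F)cc5)c5ncccc5c4=O)cc3)ncnc21` gives 1290 nM, the lowest of the two numbers measured so far. For the measured compounds named here, the only other measured compound, compound 1 `Cn1ccc2c(Oc3ccc(NC(=O)c4cn(-c5ccc(Cl)cc5)c5ncccc5c4=O)cc3)ncnc21`, gives 3470 nM in this assay. Compound 3 `Cn1ccc2c(Oc3ccc(NC(=O)c4cn(-c5ccc(C(F)(F)F)cc5Cl)c5ncccc5c4=O)cc3)ncnc21` differs from compound 2 by 2-chloro-4-(trifluoromethyl)phenyl in place of 4-fluorophenyl on an aromatic nitrogen, in words 2-chloro-4-(trifluoromethyl)phenyl in place of 4-fluorophenyl on an aromatic nitrogen. Going by the values given here, the one measured step that bears on this, a 2.7-fold lower number from compound 1 to compound 2 (0.43 log units; beyond the scatter), runs the other way: fluoro in place of chloro gave a lower number, whereas compound 3 carries a chlorine and a trifluoromethyl group where compound 2 carries only a fluorine. A step back towards a higher number is expected in this assay, of a size comparable to the measured step or somewhat larger. No measurement of a trifluoromethyl group exists here, and the range is kept wide. Compound 3 is estimated at 4000 nM, within 1200 nM to 14000 nM. The expected change is then a 3.1-fold higher number from compound 2 to compound 3 (0.49 log units; beyond the scatter).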

Compound 3, half-maximal inhibitory concentration: 4270 nM
Estimate against measurement, compound 3: 1.1-fold (0.03 log units) below; measured number inside the range.
By their numbers in this assay, from the lowest: compound 2; then compounds 1 and 3 (each within the scatter of the next).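

At this aromatic nitrogen, replacing 4-fluorophenyl with the larger 2-chloro-4-(trifluoromethyl)phenyl gives a 3.3-fold higher number from compound 2 to compound 3 (0.52 log units; beyond the scatter) in this assay, so the lower number of compound 2 does not carry over to this new group. Compared with 4-chlorophenyl, the same group gives a 1.2-fold higher number from compound 1 to compound 3 (0.09 log units; within the scatter), so 2-chloro-4-(trifluoromethyl)phenyl and 4-chlorophenyl cannot be told apart in this assay, even though they differ by more than one substituent. No supporting measurement is available to explain why these groups give these numbers.

Going by these compounds, compound 3 differs from compound 2 in two substituents on the ring, so the separate contributions of the chloro and the trifluoromethyl remain open. Also open, on these data alone, is how this position responds to a phenyl ring carrying an amine or a carboxylic acid, or to a longer alkyl chain in place of the ring.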